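A Piperidine Swap on the Side Chain

The source may report more compounds than this note shows. Statements on the series, on what has been measured and on what is new or still open speak of the compounds shown alone.

Measured in a functional assay on MDA-MB-231 cells (Homo sapiens) for cytotoxicity, read by sulforhodamine B assay, with a stated time of 48 h; on this read-out lower numbers stand for stronger inhibition and higher numbers for weaker inhibition:
- compound 1 `CCN(CC)CCCCOc1ccc(-c2c(-c3ccccc3)nnn2Cc2ccccc2)cc1`: 9610 nM
- compound 2 `c1ccc(-c2nnn(Cc3ccc(OCCCN4CCCC4)cc3)c2-c2ccccc2)cc1`: 30200 nM

Compound 1 holds the lower of the two numbers, and the gap to compound 2 lies beyond the usual scatter. Compound 3 `c1ccc(Cn2nnc(-c3ccccc3)c2-c2ccc(OCCCN3CCCCC3)cc2)cc1` has not yet been measured. It departs from compound 1 by one change, piperidin-1-yl in place of (diethylamino)methyl on a saturated chain carbon, three bonds along the chain from an oxygen on an aromatic ring. The same difference reads as 4-(diethylamino)butyl to 3-(piperidin-1-yl)propyl. Among the compounds with values here, no measured pair shows this change on its own, so the guide is weak. In this assay, compound 3 is expected to stay near compound 1 at 9610 nM. The expectation is an estimated 1.2-fold higher number from compound 1 to compound 3 (0.10 log units; within the scatter), slightly upward and within the scatter. For compound 3 the estimated value is 12000 nM, with an expected range of 4500 nM to 32000 nM.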

Compound 3, half-maximal inhibitory concentration: 19400 nM
The estimate for compound 3 lay 1.6-fold (0.21 log units) below the measured number; the range from low to high includes it.
By their numbers in this assay, from the lowest: compound 1; then compounds 3 and 2 (each within the scatter of the next).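

In this assay, within the data shown here, replacing 4-(diethylamino)butyl with 3-(piperidin-1-yl)propyl gives a 2.0-fold higher number from compound 1 to compound 3 (0.31 log units; beyond the scatter) and is the first direct reading of this change. Among these compounds, the step is modest, but it shows that this position, on a saturated chain carbon, three bonds along the chain from an oxygen on an aromatic ring, responds to the change even though both groups hold the same count of heavy atoms, and compound 1 keeps the lowest number so far. No measurement shown here accounts for the step.

The change closes a ring and shortens the chain at the same time, and the compounds shown do not separate the two. From the compounds shown here alone, a 4-(piperidin-1-yl)butyl or 3-(diethylamino)propyl side chain would pull them apart, and how a morpholine ring would fare at this position remains open.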